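The compounds below may be only part of what the source reports. "The series", "measured", "known", "first", "only" and "open" are said of these compounds alone.

Compound 1 `COc1cc(NC(=O)Nc2cc(Nc3ccc(C(C)(C)C)cc3)ncn2)cc(OC)c1` gives 32.7% in a functional assay on HCC827 cells (Homo sapiens) for inhibition, read by MTT assay, with a stated time of 48 h, tested at 10 uM; a lower number here means less inhibition, a higher number more inhibition at the concentration tested (going by the name of the read-out).
Compound 2 `COc1cc(NC(=O)Nc2cc(Nc3ccc(F)c(Cl)c3)ncn2)cc(OC)c1` gives 53.1%.
Compound 3 `CCc1cccc(Nc2cc(NC(=O)Nc3cc(OC)cc(OC)c3)ncn2)c1` gives 52.6%.

Compound 3 stands second highest of the three numbers. Its nearest neighbour is compound 2, and the step of a number 0.5 percentage points lower from compound 2 to compound 3 (within the scatter) lies within the scatter, so the two cannot be ordered. Compound 1 stands furthest away, as the step of a number 19.9 percentage points higher from compound 1 to compound 3 (beyond the scatter) shows.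

Compound 4 `COc1cc(NC(=O)Nc2cc(Nc3ccc(OC)c(C)c3)ncn2)cc(OC)c1` has not yet been measured. It differs from compound 3 in one place: 4-methoxy-3-methylphenyl in place of 3-ethylphenyl on a nitrogen on an aromatic ring.

All three measured steps alter the same group on the same nitrogen, so all bear on this change. The steps of a number 20.4 percentage points higher from compound 1 to compound 2 (beyond the scatter) and a number 19.9 percentage points higher from compound 1 to compound 3 (beyond the scatter) were modest rises when 4-(tert-butyl)phenyl was replaced, while the step of a number 0.5 percentage points lower from compound 2 to compound 3 (within the scatter) was within the scatter. Within the data shown here, none of them involves 4-methoxy-3-methylphenyl, so there is no direct precedent for the entering group. Since two quite different groups in this place gave the same number, the expected step is none beyond the scatter, with the range widened for the untested group.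

Compound 4 is therefore expected to give about 48%, between 30% and 66%. This corresponds to an expected step of a number 4.6 percentage points lower from compound 3 to compound 4 (within the scatter).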

Compound 4, a percentage reported as inhibition, at one concentration (the size of the read-out at that concentration, not a potency): 48.3%
Beside the measured number, compound 4's estimate is 0.3 percentage points below it; low and high end bracket the measured number.
By their numbers in this assay, from the lowest: compound 1; then compounds 4, 3 and 2 (each within the scatter of the next).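

In this assay, a number 4.3 percentage points lower from compound 3 to compound 4 (within the scatter) and a number 4.8 percentage points lower from compound 2 to compound 4 (within the scatter) both lie within the scatter. At this nitrogen, then, 4-methoxy-3-methylphenyl, with the oxygen and the hydrogen-bond acceptor that 3-ethylphenyl lacks, cannot be told apart from either of the two earlier replacements for 4-(tert-butyl)phenyl. The a number 15.6 percentage points higher from compound 1 to compound 4 (beyond the scatter) is beyond the scatter and modest, so compound 1 now stands apart from three differently substituted phenyl groups rather than two, and it holds the lowest number of the four. The data shown offer no measurement that could explain why these three groups read alike or why compound 1 stands apart.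

On these data alone, all four compounds keep a substituted phenyl on this nitrogen, so it remains open how the read-out would respond to an amine such as morpholine, a carboxylic acid or a longer chain such as hexyl on that ring. The rest of the shared core is identical throughout, and each number comes from a single concentration, so neither the effect of a change elsewhere in the core nor any difference in potency can be judged.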